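Oxadiazole Isomers on the Piperidine Nitrogen of a Shared Core

The source may report more compounds than this note shows. Statements on the series, on what has been measured and on what is new or still open speak of the compounds shown alone.

Three compounds share the same core and differ only in the group on an amine nitrogen in a ring. Compound 1 `COC(=O)c1cnc(N2CCC(CCCNc3ccc4c(c3)OCC4=O)CC2)nc1` gives 149 nM in a functional assay on CHO-K1 cells for agonist activity at Glucose-dependent insulinotropic receptor (Homo sapiens), read by HTRF and cAMP accumulation, with a stated time of 30 min; a lower number here means that less compound is needed, a higher number that more compound is needed for the effect. Compound 2 `CC(C)c1noc(N2CCC(CCCNc3ccc4c(c3)OCC4=O)CC2)n1` gives 73 nM in this assay, and compound 3 `CC(C)c1nc(N2CCC(CCCNc3ccc4c(c3)OCC4=O)CC2)no1` gives 161 nM. Compound 3 thus has the highest number of the three: against compound 1 it lies within the scatter, while against compound 2 the gap is beyond it, as seen in a 2.2-fold higher number from compound 2 to compound 3 (0.34 log units; beyond the scatter) and a 2.0-fold lower number from compound 1 to compound 2 (0.31 log units; beyond the scatter), with a 1.1-fold higher number from compound 1 to compound 3 (0.03 log units; within the scatter) being flat.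

Compound 4 `CC(C)c1nnc(N2CCC(CCCNc3ccc4c(c3)OCC4=O)CC2)o1` is the next isomer: 5-isopropyl-1,3,4-oxadiazol-2-yl in place of 5-isopropyl-1,2,4-oxadiazol-3-yl on an amine nitrogen in a ring. Going by the values given here, the one step that bears directly on this change is the isomer swap from compound 2 to compound 3, which was modest. The other swaps on this nitrogen were modest or flat. A modest step in either direction, or none beyond the scatter, is therefore expected, and compound 4 is estimated at 120 nM (range 45 nM to 350 nM), corresponding to an expected step of a 1.3-fold lower number from compound 3 to compound 4 (0.13 log units; within the scatter).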

Compound 4, half-maximal effective concentration: 704 nM
For compound 4 the middle estimate is 5.9-fold (0.77 log units) below the measured one, and the stated range ends below it.
By their numbers in this assay, from the lowest: compound 2; then compounds 1 and 3 (each within the scatter of the next); then compound 4.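

Isomers of the oxadiazole on this amine nitrogen in a ring are not interchangeable: although the group entering in compound 4 has the same atoms and the same counts of hydrogen-bond donors and acceptors as the one leaving, the change gives a 4.4-fold higher number from compound 3 to compound 4 (0.64 log units; beyond the scatter) in this assay. Compound 4 also stands apart from the other two compounds, with a 9.6-fold higher number from compound 2 to compound 4 (0.98 log units; beyond the scatter) and a 4.7-fold higher number from compound 1 to compound 4 (0.67 log units; beyond the scatter), so 5-isopropyl-1,3,4-oxadiazol-2-yl gives the highest number of the four. The earlier compounds shown here showed only smaller steps at this position, and this isomer widens the span reached there.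

Going by these compounds, it remains open whether this order of the isomers would hold with a cyclopropyl or tert-butyl group in place of isopropyl. Nothing shown here accounts for the difference between the isomers.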